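The source may hold more compounds than are shown below. What is called first, only, known or untested is meant among the compounds shown, and "the series" means these compounds.

Measured in a functional assay on HCT-15 cells (Homo sapiens); on this read-out lower numbers stand for an effect already at smaller amounts and higher numbers for an effect only at larger amounts of compound:
- compound 1 `COc1cc(OC)c(C2OC(c3ccc(N)c(C)c3)=NN2C(C)=O)cc1OC`: 198 uM
- compound 2 `COc1cc(C2OC(c3ccc(N(C)C)cc3)=NN2C=O)cc(OC)c1OC`: 0.096 uM

Compound 2 holds the lower of the two numbers, and the value of compound 1 lies far above it, beyond the scatter. Compound 3 `COc1cc(C2OC(c3ccc(N(C)C)cc3)=NN2C(=O)CN=[N+]=[N-])cc(OC)c1OC` keeps the core of compound 2 but has azidomethyl in place of hydrogen on a carbonyl carbon. For the measured compounds named here, no measured pair shows this change directly, so any forecast in this assay is uncertain. The expected change is a 6.3-fold higher number from compound 2 to compound 3 (0.80 log units; beyond the scatter), toward a higher number and beyond the scatter. For compound 3 the estimated value is 0.6 uM, with an expected range from 0.06 uM to 8 uM.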

Compound 3, concentration for half-maximal effect: 0.15 uM
Beside the measured number, compound 3's estimate is 4.0-fold (0.60 log units) above it; the measured number falls inside the stated range.
By their numbers in this assay, from the lowest: compounds 2 and 3 (each within the scatter of the next); then compound 1.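

In this assay the change from formyl to (azidomethyl)carbonyl on the ring amide-type nitrogen leaves the number within the scatter (a 1.6-fold higher number from compound 2 to compound 3 (0.19 log units; within the scatter)). For the compounds shown here, this position therefore tolerates azidomethyl in place of hydrogen on the carbonyl carbon, a step the earlier compounds did not show. No measured evidence is available to explain this result.

The compounds shown leave open how an amine, a carboxylic acid or a longer chain at this carbonyl carbon would read. They also leave open whether azidomethyl would be tolerated as well on a different core.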